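Removing the methoxy from a thiazole already at the limit

The source may report more compounds than this note shows. Statements on the series, on what has been measured and on what is new or still open speak of the compounds shown alone.

Compound 3 `COc1ccc(Nc2nc(-n3ccnc3)cs2)cc1` gives only a limit in a functional assay on RKO cells (Homo sapiens) for cytotoxicity, read by resazurin assay, with a stated time of 72 h; a lower number here means a stronger inhibitor, a higher number a weaker inhibitor: its value of > 100000 nM is the edge of the assay, not a number, and it stands with the limit of > 100000 nM in this assay, at which 1 of the 3 values shown sits. Compound 2 `COc1ccc(Nc2nc(-n3cc(C)nc3C)cs2)cc1` gives 250 nM in this assay, and the step of an at least 400-fold higher number from compound 2 to compound 3 (2.60 log units; beyond the scatter) is large. Compound 1 `Cc1nccn1-c1csc(Nc2ccccc2)n1` gives 32500 nM in this assay, but it differs from the others in more than one place. Compound 4 `c1ccc(Nc2nc(-n3ccnc3)cs2)cc1` differs from compound 3 by hydrogen in place of methoxy on an aromatic carbon. Among the measured compounds shown here, no measured step isolates this change; the values of compound 1 and compound 2 do not separate it from the imidazole change. Compound 3 sits at the limit of > 100000 nM. Compound 4 is therefore expected to give 150000 nM (range 60000 nM to 500000 nM), an estimated step that the limit leaves unreadable from compound 3 to compound 4 that most likely remains a limit.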

Compound 4, half-maximal inhibitory concentration: > 100000 nM
Compound 4: no number, only a limit (the forecaster's own chance of this, stated with the estimate: 85%); the middle value lies beyond the limit too.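

In this assay compound 4 gives only a limit, not a number, so the step from methoxy to hydrogen cannot be read: the limit of > 100000 nM in this assay, at which 2 of the 4 values shown sit.

The step that can be read is an at least 3.0-fold higher number from compound 1 to compound 4 (0.48 log units; beyond the scatter). Without the methoxy, then, loss of a methyl from the imidazole also gives a higher number, the same direction as in the methoxy pair.

From the compounds shown here alone, what the methoxy itself contributes stays open. The compounds shown also leave open how an amine or a carboxylic acid at that place would read.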